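Tetrazole for carboxylic acid on a cyclohexyl amide

The compounds below may be only part of what the source reports. "The series", "measured", "known", "first", "only" and "open" are said of these compounds alone.

Compound 1 `CC[C@]1(C(=O)O)CC[C@H](C(=O)N2CC[C@](c3ccc(C(F)(C(F)(F)F)C(F)(F)F)cc3)(S(=O)(=O)c3ccc(F)cc3)C2)CC1`: "not determined" (no result reported)
Compound 2 `C[C@]1(C(=O)N2CC[C@](c3ccc(C(F)(C(F)(F)F)C(F)(F)F)cc3)(S(=O)(=O)c3ccc(F)cc3)C2)CC[C@@H](C(=O)O)CC1`: 100%

Going by the values given here, in an ADME assay on microsomes from liver (Mus musculus) for metabolic stability, with a stated time of 10 min (on this read-out higher numbers stand for a more stable compound and lower numbers for a less stable compound), compound 2 gives 100%, the only number obtained here, since for compound 1 the outcome is "not determined" (no result reported). Compound 3 `O=C([C@H]1CC[C@H](c2nnn[nH]2)CC1)N1CC[C@](c2ccc(C(F)(C(F)(F)F)C(F)(F)F)cc2)(S(=O)(=O)c2ccc(F)cc2)C1` differs from compound 2 in one place: 4-(1H-tetrazol-5-yl)cyclohexyl in place of 4-carboxy-1-methylcyclohexyl on a carbonyl carbon. Among the compounds with values here, no measured step between two compounds is available, so the size of the change can only be expected. Compound 3 is expected to stay within the scatter of compound 2, with an estimated step of a number 8 percentage points lower from compound 2 to compound 3 (within the scatter). Compound 3 is therefore estimated at 92%, between 72% and 100%.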

Compound 3, percent of the compound remaining: 73%
Estimate against measurement, compound 3: 19 percentage points above; measured number inside the range.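

In this assay, this position on the carbonyl carbon now has its first measured step: 4-(1H-tetrazol-5-yl)cyclohexyl in place of 4-carboxy-1-methylcyclohexyl gives a number 27 percentage points lower from compound 2 to compound 3 (beyond the scatter), so the change is not neutral on this read-out. The swap replaces the carboxylic acid with the tetrazole and also removes the methyl group, so the step covers both differences together. Nothing available bears on the reason for this step.

From the compounds shown here alone, what remains open is which of the two differences carries the step. A plain 4-carboxycyclohexyl group, or a 1-methylcyclohexyl group bearing the tetrazole, would separate them.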